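The source may report more compounds than this note shows. Statements on the series, on what has been measured and on what is new or still open speak of the compounds shown alone.

Working notes on the aryl ester series. Of the compounds shown here, three have been measured in an assay on NIH3T3 cells with Urotensin-2 receptor (Homo sapiens) as the target; on this read-out higher numbers stand for an effect only at larger amounts of compound and lower numbers for an effect already at smaller amounts. Compound 1 `CN(C)CCC(OC(=O)c1cn(C)c2ccccc12)c1ccc(Cl)cc1` gives 1510 nM, compound 2 `CN(C)CCC(OC(=O)c1ccc(C(F)(F)F)cc1)c1ccc(Cl)cc1` gives 1740 nM, and compound 3 `COc1cccc(C(=O)OC(CCN(C)C)c2ccc(Cl)cc2)c1C` gives 1950 nM. Compound 2 stands second highest of the three numbers, but its gap to compound 3 and its gap to compound 1 both lie within the scatter, so the three aryl esters sit together on this read-out. Compound 4 `Cc1ccc(C(=O)OC(CCN(C)C)c2ccc(Cl)cc2)cc1` differs from compound 2 by methyl in place of trifluoromethyl on an aromatic carbon. Among the compounds with values here, no measured pair isolates this change. Since the three measured aryl groups give numbers within the scatter of one another, no step beyond the scatter is expected in this assay. The expected step is a 1.0-fold higher number from compound 2 to compound 4 (0.01 log units; within the scatter). Compound 4 is accordingly estimated at 1800 nM, with a range from 800 nM to 4000 nM.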

Compound 4, half-maximal effective concentration: 2750 nM
For compound 4 the middle estimate is 1.5-fold (0.18 log units) below the measured one; low and high end bracket the measured number.
By their numbers in this assay, from the lowest: compounds 1, 2, 3 and 4 (each within the scatter of the next).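

Within the data shown here, this is the first pair that isolates a single change: in this assay, methyl in place of trifluoromethyl on the aromatic carbon para to a large group gives a 1.6-fold higher number from compound 2 to compound 4 (0.20 log units; within the scatter). This step lies within the scatter, so the read-out does not separate these two groups at this position. No measurement at hand bears on what lies behind this result. From the compounds shown here alone, whether an amine, a carboxylic acid or a longer chain at this position would give a step beyond the scatter stays open.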